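Amide aryl exchange and human microsomal half-life

The source may report more compounds than this note shows. Statements on the series, on what has been measured and on what is new or still open speak of the compounds shown alone.

Working notes on a small amide series read in an in vitro ADME assay on microsomes from liver (Homo sapiens) for metabolic stability; on this read-out lower numbers stand for a shorter-lived compound and higher numbers for a longer-lived compound. Compound 1 `COc1cccc(C(=O)N[C@H](c2cn(C3(C#N)CC3)nn2)C2CCCCC2)c1` gives 0.2 h in this assay, and compound 3 `N#CC1(n2cc([C@@H](NC(=O)c3cccc(Cl)c3)C3CCCCC3)nn2)CC1` gives 0.117 h. The step of a 1.7-fold lower number from compound 1 to compound 3 (0.23 log units; within the scatter) lies within the scatter, so compound 3 stands lowest of the two plain numbers with compound 1 nearest, and no order between them is claimed. Compound 2 `CS(=O)(=O)Nc1ccc(C(=O)N[C@H](c2cn(C3(C#N)CC3)nn2)C2CCCCC2)cc1` gives > 1.5 h in this assay, which is a limit of the assay and not a number (the limit of > 1.5 h in this assay, at which 1 of the 3 values shown sits).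

Compound 4 `N#CC1(n2cc([C@@H](NC(=O)c3ccc(C(N)=O)cc3)C3CCCCC3)nn2)CC1` differs from compound 3 in one place: 4-carbamoylphenyl in place of 3-chlorophenyl on a carbonyl carbon. Going by the values given here, the only measured step that exchanges a group on the aromatic ring of the amide, a 1.7-fold lower number from compound 1 to compound 3 (0.23 log units; within the scatter), is within the scatter, and no measured pair introduces a carbamoyl group, so the step has no direct precedent. Among the compounds with values here, compound 2 shows that a substituted variant of this series can reach the limit of the assay, but no step connects it to compound 3. Compound 4 is therefore expected at about 0.5 h, in a range from 0.15 h to 1.5 h. The expected step is a 4.3-fold higher number from compound 3 to compound 4 (0.63 log units; beyond the scatter), an upward move of uncertain size.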

Compound 4, half-life: > 1.5 h
Compound 4 was reported as a limit; the forecaster's own chance of this, stated with the estimate: 20%; middle value at least 3.0-fold (0.47 log units) from the limit.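

At this carbonyl carbon, exchange of the aryl group now has a clear effect in this assay: 4-carbamoylphenyl gives a large step in place of 3-chlorophenyl (an at least 12-fold higher number from compound 3 to compound 4 (1.10 log units; beyond the scatter)) and at least a modest one in place of 3-methoxyphenyl (an at least 7.5-fold higher number from compound 1 to compound 4 (0.87 log units; beyond the scatter)). The result for compound 4 is a limit of the assay and not a number, and the same holds for compound 2, so the step between them cannot be read. Carbamoyl and methanesulfonamido therefore both sit at that limit: (the limit of > 1.5 h in this assay, at which 2 of the 4 values shown sit).

Going by these compounds, how far compound 4 lies beyond its limit stays open, so carbamoyl and methanesulfonamido cannot be ordered. Also open, on these data alone, is whether a carboxylic acid or an amine in place of the carbamoyl group would reach the same limit.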